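Swapping Cyano for Fluoro in a Small Series

The source may report more compounds than this note shows. Statements on the series, on what has been measured and on what is new or still open speak of the compounds shown alone.

In a functional assay on the whole organism (Gastrocnemius, strain Sprague-Dawley) for inhibition, with Rattus norvegicus as the target (a lower number here means that less compound is needed, a higher number that more compound is needed for the effect), compound 1 `O=C1NC(=O)N(/N=C/c2ccc(-c3ccc(Cl)cc3)o2)C1O` gives 0.016 umol/kg, compound 2 `N#Cc1ccc(-c2ccc(/C=N/N3C(=O)NC(=O)C3O)o2)cc1` gives 0.025 umol/kg and compound 3 `O=C1NC(=O)N(/N=C/c2ccc(-c3cccc(C(F)(F)F)c3)o2)C1O` gives 0.096 umol/kg. Compound 2 therefore lies within the usual scatter of compound 1, while the number for compound 3 is clearly higher than that for compound 2. Compound 4 `O=C1NC(=O)N(/N=C/c2ccc(-c3ccc(F)cc3)o2)C1O` carries fluoro in place of cyano on an aromatic carbon. Among the compounds with values here, the one measured step of this kind, cyano in place of chloro on an aromatic carbon, gave a 1.6-fold higher number from compound 1 to compound 2 (0.19 log units; within the scatter). Within the data shown here, no step beyond the scatter is therefore expected, although no fluoro compound has been measured yet. The expected size is a 1.2-fold higher number from compound 2 to compound 4 (0.08 log units; within the scatter). Compound 4 is estimated at 0.03 umol/kg, with an expected range of 0.012 umol/kg to 0.075 umol/kg.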

Compound 4, dose for half-maximal effect: 0.091 umol/kg
Compound 4: the middle estimate sits 3.0-fold (0.48 log units) below what was measured; measured number outside the range, above it.
By their numbers in this assay, from the lowest: compounds 1 and 2 (each within the scatter of the next); then compounds 4 and 3 (each within the scatter of the next).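

In this assay the group at this place on the ring clearly matters: putting fluoro in place of cyano gives a 3.6-fold higher number from compound 2 to compound 4 (0.56 log units; beyond the scatter) in this comparison, and putting fluoro in place of chloro gives a 5.7-fold higher number from compound 1 to compound 4 (0.75 log units; beyond the scatter) in the second. Chloro and cyano stayed within the scatter of each other, so fluoro is the first of these groups to separate from both. Nothing measured here explains this separation.

From the compounds shown here alone, whether bromo, an amine or a carboxylic acid at this place would group with fluoro or with chloro and cyano remains open. Also open, going by these compounds, is whether fluoro would give a similar step at other places on the ring.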